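The source may hold more compounds than are shown below. What is called first, only, known or untested is meant among the compounds shown, and "the series" means these compounds.

Working notes on the series. For the measured compounds named here, in a physicochemical assay for solubility, in phosphate buffer, at pH 7.2 (a lower number here means a less soluble compound, a higher number a more soluble compound), compound 1 (`COc1cc(C2CN(C(=O)c3cc(OCCO)ccn3)C2)ccc1OCc1ccc(C2CC2)cc1`) gives 800 nM, the lower of the two numbers so far. Compound 2 (`COc1ccc(COc2ccc(C3CN(C(=O)c4cc(OCCO)ccn4)C3)cc2OC)cc1`) gives 5600 nM.

Compound 3 (`COc1cc(C2CN(C(=O)c3cc(OC[C@H](O)CO)ccn3)C2)ccc1OCc1ccc(C2CC2)cc1`) has not been measured. It keeps the cyclopropyl group of compound 1 and differs in one place, where 2-hydroxyethoxy becomes 2,3-dihydroxypropoxy: hydroxymethyl in place of hydrogen on a saturated chain carbon bound to an oxygen on a saturated carbon and a saturated chain carbon.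

Going by the values given here, the only measured step, a 7.0-fold higher number from compound 1 to compound 2 (0.85 log units; beyond the scatter), is methoxy in place of cyclopropyl on an aromatic carbon. It lies at a different place from the new change, so it offers a rough scale for a single change in this series and no direction. Among the compounds with values here, no measured pair covers hydroxymethyl in place of hydrogen on a saturated chain carbon. The direction is therefore a judgement, and a modest move to a higher number in this assay, smaller than the step to compound 2, is expected. The expected step is a 1.8-fold higher number from compound 1 to compound 3 (0.24 log units; within the scatter). For compound 3 the estimate is 1400 nM, with an expected range of 500 nM to 4000 nM.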

Compound 3, solubility: 2700 nM
Compound 3: middle estimate off by 1.9-fold (0.29 log units), on the low side; the measured number falls inside the stated range.
By their numbers in this assay, from the lowest: compound 1; then compound 3; then compound 2.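

For the compounds shown here, the change from 2-hydroxyethoxy to 2,3-dihydroxypropoxy is the first measured change at this place, and in this assay it gives a 3.4-fold higher number from compound 1 to compound 3 (0.53 log units; beyond the scatter), with the cyclopropyl group kept. Compound 1 and compound 2 differ only at the cyclopropyl group, so they gave no direction for the chain; this one pair now shows that hydroxymethyl in place of hydrogen, on a saturated chain carbon bound to an oxygen on a saturated carbon and a saturated chain carbon, moves the number up by more than the usual scatter. No measurement in hand bears on the reason for this step.

Whether the same change gives a similar step with the methoxy group of compound 2 in place of the cyclopropyl group remains open, since this change is shown on one background only. Also open, as far as these compounds go, is how other groups would behave at this place, such as an amine, a carboxylic acid or a longer chain carrying further hydroxyl groups, and one pair cannot establish a trend for this chain.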